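The source may hold more compounds than are shown below. What is called first, only, known or untested is meant among the compounds shown, and "the series" means these compounds.

Measured compounds in a functional assay on HeLa cells (Homo sapiens) for cytotoxicity, read by neutral red uptake, with a stated time of 3 days; on this read-out higher numbers stand for weaker inhibition and lower numbers for stronger inhibition:

- Compound 1, `CCCCc1c(F)c(N)c2c(=O)cc(-c3ccc(N)c(F)c3)oc2c1F`. Compound 1 gives > 100000 nM, which is a limit of the assay and not a number.
- Compound 2, `CCCCCCc1c(F)c(N)c2c(=O)cc(-c3ccc(N)c(F)c3)oc2c1F`. Compound 2 gives 21000 nM.
- Compound 3, `Nc1ccc(-c2cc(=O)c3c(N)c(F)c(O)c(F)c3o2)cc1F`. Compound 3 gives > 100000 nM, which is a limit of the assay and not a number.

Compound 2 is therefore the only one of the three with an actual number in this assay; the other two stop at the limit of > 100000 nM in this assay, at which 2 of the 3 values shown sit.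

Compound 4, `CN(C)CCCOCc1c(F)c(N)c2c(=O)cc(-c3ccc(N)c(F)c3)oc2c1F`, differs from compound 2 in the chain attached to the shared core: 3-(dimethylamino)propoxy in place of pentyl on a saturated chain carbon bound to an aromatic carbon.

For the measured compounds named here, two measured steps touch this chain. Lengthening it gave an at least 4.7-fold lower number from compound 1 to compound 2 (0.67 log units; beyond the scatter), and removing it altogether gave an at least 4.7-fold higher number from compound 2 to compound 3 (0.67 log units; beyond the scatter). Both point the same way: a longer plain chain goes with a lower number, and losing the chain goes with a higher one. Compound 4 keeps a chain of similar length but changes what it is made of, so these steps do not settle the outcome, and a number in either direction within a modest range would not be surprising.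

On balance, compound 4 is expected to give a somewhat higher number, so the expected step is a 2.1-fold higher number from compound 2 to compound 4 (0.33 log units; beyond the scatter). The estimate for compound 4 in this assay is 45000 nM, with a range from 12000 nM to 150000 nM.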

Compound 4, half-maximal inhibitory concentration: 12000 nM
Estimate against measurement, compound 4: 3.8-fold (0.57 log units) above; measured number inside the range.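

In this assay, 3-(dimethylamino)propoxy in place of pentyl on a saturated chain carbon bound to an aromatic carbon gives a 1.8-fold lower number from compound 2 to compound 4 (0.24 log units; within the scatter), so the two chains cannot be told apart on this read-out. The earlier compounds shown here linked the lower number only to plain carbon chains, whereas compound 4 shows that a chain containing nitrogen and oxygen can also stand apart from the shorter butyl and from hydroxy, with an at least 8.3-fold lower number from compound 1 to compound 4 (0.92 log units; beyond the scatter) and an at least 8.3-fold lower number from compound 3 to compound 4 (0.92 log units; beyond the scatter). Compound 1 and compound 3 each rest on a limit and not on a number, so these two steps give only a minimum size: the limit of > 100000 nM in this assay, at which 2 of the 4 values shown sit.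

From the compounds shown here alone, what remains open is which part of the new chain matters, since a chain ending in a simple methoxy group with no amine, or a plain alkyl chain ending in a dimethylamino group with no oxygen, would separate the two contributions. Going by these compounds, it is also open whether a longer chain or a carboxylic acid at the chain end would move the number beyond the scatter of compound 2 and compound 4.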